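The compounds below may be only part of what the source reports. "The series", "measured", "known", "first", "only" and "open" are said of these compounds alone.

Measured in an ADME assay on MT4 cells (Homo sapiens) for cytotoxicity, read by MTT assay, with a stated time of 96 h; a higher number here means that more compound is tolerated, a lower number that less compound is tolerated:
- Compound 1 `CN(Cc1ccccc1)/N=N/c1ccccc1`: >= 100000 nM, a limit
- Compound 2 `CN(/N=N/c1cccc([N+](=O)[O-])c1)c1ccccc1`: > 100000 nM, a limit
- Compound 3 `Fc1ccc(/N=N/c2ccc(NC[C@@H]3CCCN4CCCC[C@H]34)c3c2CCCC3)c(F)c1`: 51000 nM

Compound 1 stands at >= 100000 nM, which is a limit of this assay and not a number. Compound 2 likewise gives only a limit, > 100000 nM. Compound 3 alone gives a number, 51000 nM.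

Compound 4 `c1ccc(CN/N=N/c2ccccc2)cc1` keeps the core of compound 1, with hydrogen in place of methyl on an amine nitrogen. For the measured compounds named here, no measured step shows what this change does in this assay. A modest move toward less compound tolerated is expected, or none beyond the scatter. The estimated step of an at least 1.2-fold lower number from compound 1 to compound 4 (0.09 log units; that floor lies within the scatter) is therefore small. For compound 4 the expected value is 80000 nM, with an estimated range of 30000 nM to 100000 nM.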

Compound 4, half-maximal cytotoxic concentration: 42000 nM
The estimate for compound 4 lay 1.9-fold (0.28 log units) above the measured number, and the stated range covers the measured number.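

In this assay, hydrogen in place of methyl on an amine nitrogen gives an at least 2.3-fold lower number from compound 1 to compound 4 (0.37 log units; beyond the scatter). This is the only step shown, and it shows that this one change at this position is enough to bring a limit down to a measurable value. The true size of the step stays unknown because compound 1 reads only as a limit: the limit of >= 100000 nM in this assay, at which 1 of the 4 values shown sits.

The compounds shown leave open whether an ethyl group or a longer chain on this amine nitrogen would behave like methyl or like hydrogen. They also leave open whether the same change would act alike on the core of compound 2.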